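The compounds below may be only part of what the source reports. "The series", "measured", "known", "first", "only" and "open" are said of these compounds alone.

Measured in a functional assay on V79 cells (Cricetulus griseus) for cytotoxicity, read by colony formation; on this read-out higher numbers stand for weaker inhibition and lower numbers for stronger inhibition:
- compound 1 `CCNCC1CCN(c2c(F)cc3c(=O)c(C(=O)O)cn(C4CC4)c3c2F)C1`: 11 ug/mL; 11 ug/mL; 11 ug/mL; 11 ug/mL (4 entries)
- compound 2 `NCC1CCN(c2c(F)cc3c(=O)c(C(=O)O)cn(C4CC4)c3c2F)C1`: 11 ug/mL

Compound 2 has one number in this assay, 11 ug/mL, and one further entry that gives no single number. The four entries for compound 1 all read 11 ug/mL; 11 ug/mL; 11 ug/mL; 11 ug/mL (4 entries), so the two compounds show the same value.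

Compound 3 `O=C(O)c1cn(C2CC2)c2c(F)c(N3CCNCC3)c(F)cc2c1=O` keeps the shared core but has piperazin-1-yl in place of 3-(aminomethyl)pyrrolidin-1-yl on an aromatic carbon. This swaps a five-membered non-aromatic ring for a six-membered one with 2 hetero atoms.

Compound 1 and compound 2 both carry the five-membered ring, so neither shows what replacing it does. Among the compounds with values here, no measured step covers this change, which makes any forecast a judgement with wide margins. A modest move towards weaker inhibition seems the most likely outcome, though no change at all would not be surprising. The expected size of the move is a 2.3-fold higher number from compound 2 to compound 3 (0.36 log units; beyond the scatter). For compound 3 the estimated value is 25 ug/mL, with an expected range of 8 ug/mL to 80 ug/mL.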

Compound 3, half-maximal inhibitory concentration: 47 ug/mL
Estimate against measurement, compound 3: 1.9-fold (0.27 log units) below; the measured number falls inside the stated range.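

In this assay, piperazin-1-yl in place of 3-(aminomethyl)pyrrolidin-1-yl on this aromatic carbon gives a 4.3-fold higher number from compound 2 to compound 3 (0.63 log units; beyond the scatter), which means weaker inhibition of colony formation. Compound 1 and compound 2 both carry the five-membered ring and show the same value, so only compound 3 reveals that the read-out responds when this ring is exchanged. Nothing among the data shown accounts for the shift, so the result describes what happened without explaining it.

This single step changes the ring size and the arrangement of the two nitrogens together, so the compounds shown do not separate the contribution of each. On these data alone, it also remains open whether a morpholin-4-yl or a 4-methylpiperazin-1-yl group on the same carbon would read close to compound 3 or close to compound 2.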